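The compounds below may be only part of what the source reports. "The series", "measured", "known", "first", "only" and "open" are said of these compounds alone.

In a toxicity assay on THP-1 cells (Homo sapiens) for inhibition (on this read-out lower numbers stand for higher toxicity in this test and higher numbers for lower toxicity in this test), compound 1 `COc1ccc(-c2cnc(NC(=O)c3ccccc3O)n2C)cc1` gives > 100000 nM, a limit of the assay and not a number. Compound 2 `COc1ccc(-c2cnc(NC(=O)c3ccc(O)cc3)n2C)cc1` gives > 100000 nM, which is likewise a limit, so this is the only position known for it. Both measured compounds therefore share one reading: the limit of > 100000 nM in this assay, at which 2 of the 2 values shown sit. Compound 3 `COc1ccc(-c2cnc(NC(=O)c3cccc(O)c3)n2C)cc1` keeps the core of compound 2 and carries 3-hydroxyphenyl in place of 4-hydroxyphenyl on a carbonyl carbon. For the measured compounds named here, the one measured step that bears on this change is an exchange at the same place, a step that the two limits leave unreadable from compound 1 to compound 2, and it gives no size to carry over. No change beyond the scatter is therefore expected, in either direction. The expected step is a number no higher from compound 2 to compound 3 (the limit leaves the size open). The estimate for compound 3 is 100000 nM, with an expected range from 40000 nM to 200000 nM.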

Compound 3, half-maximal cytotoxic concentration: > 100000 nM
Compound 3 was reported as a limit (the forecaster's own chance of this, stated with the estimate: 85%); the middle value lies on the limit itself.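

For the compounds shown here, no step among compound 1, compound 2 and compound 3 can be read, since each reading is a limit of the assay and not a number: the limit of > 100000 nM in this assay, at which 3 of the 3 values shown sit. In this assay the compounds shown leave open whether 2-hydroxyphenyl, 3-hydroxyphenyl and 4-hydroxyphenyl differ at all.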